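Six-membered heteroaryl swaps on a shared pyrazole acid core

This account rests on a few compounds, and the source may have more. Where it says the series, first, only, none or still open, it means among the compounds named here.

Compound 1 `Cc1nn(-c2nc(-c3ccc(Cl)c(Cl)c3)c(SC(C)C)s2)c(C(=O)O)c1-c1cncnc1`: 22000 nM
Compound 2 `Cc1nn(-c2nc(-c3ccc(Cl)c(Cl)c3)c(SC(C)C)s2)c(C(=O)O)c1-c1cnn(C)c1`: 6800 nM
Compound 3 `Cc1nn(-c2nc(-c3ccc(Cl)c(Cl)c3)c(SC(C)C)s2)c(C(=O)O)c1-c1cnccn1`: 14000 nM

In a functional assay on BJAB cells (Homo sapiens) for antiproliferative activity, with a stated time of 4 days (on this read-out higher numbers stand for an effect only at larger amounts of compound and lower numbers for an effect already at smaller amounts), compound 3 gives the second highest of the three numbers; it sits within the scatter of compound 1 a 1.6-fold lower number from compound 1 to compound 3 (0.20 log units; within the scatter) and differs modestly from compound 2 a 2.1-fold higher number from compound 2 to compound 3 (0.31 log units; beyond the scatter). Compound 4 `Cc1nn(-c2nc(-c3ccc(Cl)c(Cl)c3)c(SC(C)C)s2)c(C(=O)O)c1-c1cccnc1` carries pyridin-3-yl in place of pyrazin-2-yl on an aromatic carbon. Among the measured compounds shown here, no measured step swaps these two groups directly. The closest guide is the exchange of one six-membered ring with two nitrogens for another a 1.6-fold lower number from compound 1 to compound 3 (0.20 log units; within the scatter), which stayed within the scatter, while only the move to a five-membered ring a 3.2-fold lower number from compound 1 to compound 2 (0.51 log units; beyond the scatter) went beyond it. A small step, within the scatter, is therefore expected for compound 4 a 1.2-fold lower number from compound 3 to compound 4 (0.07 log units; within the scatter). Compound 4 is estimated at 12000 nM, between 5000 nM and 30000 nM.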

Compound 4, half-maximal effective concentration: 12000 nM
For compound 4 middle estimate and measured number coincide at the digits printed; the range from low to high includes it.
By their numbers in this assay, from the lowest: compounds 2, 4, 3 and 1 (each within the scatter of the next, the first and the last beyond it).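

In this assay, pyridin-3-yl, a six-membered aromatic ring with 1 hetero atom, stays within the scatter of all three earlier groups at this position (a 1.2-fold lower number from compound 3 to compound 4 (0.07 log units; within the scatter); a 1.8-fold lower number from compound 1 to compound 4 (0.26 log units; within the scatter); a 1.8-fold higher number from compound 2 to compound 4 (0.25 log units; within the scatter)). So 1-methyl-1H-pyrazol-4-yl, which stood beyond the scatter of the two rings with 2 hetero atoms, does not stand apart from pyridin-3-yl. No measurement here accounts for these small differences. The compounds shown leave open whether a plain phenyl ring or an aminopyridine at this position would stand apart from these groups.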